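Removing the iodo substituent from compound 1

A few compounds are considered here, and "the series" means these few. Any claim that something is new, unique, unknown or untested is made for them only; others in the source may bear on it.

Measured compounds:
compound 1, `COc1ccc(-c2c(I)c(=O)c3c(OC)cc(OC)cc3n2S(=O)(=O)c2ccc(OC)cc2)cc1` — 8580 nM
compound 2, `COc1ccc(-c2cc(=O)c3c(OC)cc(OC)cc3n2S(=O)(=O)c2ccc([N+](=O)[O-])cc2)cc1` — 17300 nM
compound 3, `COc1ccc(-c2cc(=O)c3c(OC)cc(OC)cc3n2S(=O)(=O)c2ccc(Cl)cc2)cc1` — the value here is a limit of the assay

In a functional assay on KOPN-8 cells (Homo sapiens) for antiproliferative activity, with a stated time of 72 h (a lower number here means that less compound is needed, a higher number that more compound is needed for the effect), compound 1 gives 8580 nM. Compound 2 gives 17300 nM, a number that lies within the usual scatter of that of compound 1, so the two cannot be ordered. Compound 3 reaches only a limit of the assay, > 34400 nM. For the measured compounds named here, the one step that can be read directly, an at least 1.9-fold higher number from compound 2 to compound 3 (0.29 log units; that floor lies within the scatter), concerns the substituent on the sulfonyl-bearing ring and has the floor described by the limit of > 34400 nM in this assay, at which 1 of the 3 values shown sits.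

Compound 4, `COc1ccc(-c2cc(=O)c3c(OC)cc(OC)cc3n2S(=O)(=O)c2ccc(OC)cc2)cc1`, differs from compound 1 as follows: hydrogen in place of iodo on an aromatic carbon. Going by the values given here, no measured step touches this position on the shared core, and the one step on record concerns a different part of the molecule, so it gives no direct guide. The account therefore leans on compound 1 alone, with the expectation that removing the iodo group leaves the number in the same region or moves it modestly higher, the step being estimated as a 1.7-fold higher number from compound 1 to compound 4 (0.24 log units; within the scatter).

Compound 4 is accordingly expected to give about 15000 nM in this assay, with a likely range from 5000 nM to 45000 nM.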

Compound 4, half-maximal effective concentration: > 82700 nM
Compound 4 was reported as a limit; the forecaster's own chance of this, stated with the estimate: 25%; middle value at least 5.5-fold (0.74 log units) from the limit.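

In this assay compound 4 reaches only a limit of the assay, > 82700 nM. Hydrogen in place of iodo gives an at least 9.6-fold higher number from compound 1 to compound 4 (0.98 log units; beyond the scatter), so this aromatic carbon, which no earlier step touched, is shown to matter for the antiproliferative read-out, with the compound that keeps iodo needing less compound for the effect. Methoxy in place of nitro gives an at least 4.7-fold higher number from compound 2 to compound 4 (0.67 log units; beyond the scatter), which means that the substituent on the sulfonyl-bearing ring, whose only earlier step had a floor within the scatter, now also shows a step beyond it, while the step between compound 3 and compound 4 cannot be read, as both ends are limits.

The compounds shown leave open whether iodo itself is needed on this aromatic carbon, or whether another group there, such as bromo, a methyl group or an amine, would keep the number in the region of compound 1. They also leave open whether iodo would give a step of similar size on a core carrying nitro or chloro in place of the methoxy group on the sulfonyl-bearing ring.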